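A few compounds are considered here, and "the series" means these few. Any claim that something is new, unique, unknown or untested is made for them only; others in the source may bear on it.

In a functional assay on cells for antagonist activity at Free fatty acid receptor 1 (Homo sapiens), read by TR-FRET and inositol phosphate accumulation, with a stated time of 2 h (a higher number here means a weaker inhibitor, a lower number a stronger inhibitor), compound 1 `CC(=O)Nc1ccccc1OCc1cc(C)nc(-c2ccccn2)n1` is reported only as a limit, > 39800 nM, which is the limit of > 39800 nM in this assay, at which 1 of the 2 values shown sits. Compound 2 `COc1cc(COc2cccc(F)c2)nc(-c2ccccn2)n1` gives 1260 nM in this assay, the only actual number among the results shown. Compound 3 `CN(C)c1cc(COc2cccc(F)c2)nc(-c2ccccn2)n1` has not yet been tested; it differs from compound 2 by dimethylamino in place of methoxy on an aromatic carbon, a dimethylamino in place of methoxy on an aromatic carbon. Among the compounds with values here, no measured pair shows the effect of this exchange, so the expected step, a 1.2-fold higher number from compound 2 to compound 3 (0.08 log units; within the scatter), is no larger than the usual scatter of repeated measurements. Compound 3 is therefore estimated at 1500 nM, with a range from 500 nM to 5000 nM.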

Compound 3, half-maximal inhibitory concentration in the Free fatty acid receptor 1 assay: 1580 nM
Compound 3: middle estimate off by 1.1-fold (0.02 log units), on the low side, within the range that was stated.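

Within the data shown here, in the Free fatty acid receptor 1 assay, the exchange gives the first reading at this position: dimethylamino in place of methoxy on this aromatic carbon, opposite the ring nitrogen, yields a 1.3-fold higher number from compound 2 to compound 3 (0.10 log units; within the scatter), so the two groups cannot be told apart here. In the Free fatty acid receptor 1 assay compound 2 gives 1260 nM and compound 3 gives 1580 nM. In a physicochemical assay for lipophilicity, at pH 7.4 (on this read-out higher numbers stand for higher lipophilicity and lower numbers for lower lipophilicity), the same exchange yields no change at the digits printed from compound 2 to compound 3 (within the scatter), so the two compounds also match on this read-out. In the physicochemical assay compound 2 gives 3.6 and compound 3 gives 3.6. Nothing shown gives a cause for this outcome. From the compounds shown here alone, whether a carboxylic acid or a longer chain on this carbon would give a step beyond the scatter remains open.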